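The source may hold more compounds than are shown below. What is called first, only, known or untested is meant among the compounds shown, and "the series" means these compounds.

Going by the values given here, in a functional assay on M21 cells (Homo sapiens) for antiproliferative activity, read by sulforhodamine B assay, with a stated time of 48 h (a higher number here means a weaker inhibitor, a lower number a stronger inhibitor), three compounds sharing one core have numbers so far. Compound 3 `O=C1NCCN1c1ccc(S(=O)(=O)Nc2ccccc2)cc1`, with hydrogen on the aromatic carbon in question, gives 200 nM. Compound 1 `O=C1NCCN1c1ccc(S(=O)(=O)Nc2ccc(F)cc2)cc1`, with fluoro there, gives 230 nM, and a 1.2-fold lower number from compound 1 to compound 3 (0.06 log units; within the scatter) leaves the two level with each other. Compound 2 `CCc1ccc(NS(=O)(=O)c2ccc(N3CCNC3=O)cc2)cc1`, with ethyl there, gives 480 nM. It stands apart from both others, with a 2.1-fold higher number from compound 1 to compound 2 (0.32 log units; beyond the scatter) and a 2.4-fold lower number from compound 2 to compound 3 (0.38 log units; beyond the scatter). Compound 3 therefore shares the low end of this small set with compound 1.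

Compound 4 `O=C1NCCN1c1ccc(S(=O)(=O)Nc2ccc(OC(F)F)cc2)cc1` differs from compound 3 in one place: difluoromethoxy in place of hydrogen on an aromatic carbon, para to a large group. Among the compounds with values here, no measured compound carries this group, so the only guides are the two steps at that same carbon. Fluoro in compound 1 made no difference beyond the scatter, as a 1.2-fold lower number from compound 1 to compound 3 (0.06 log units; within the scatter) shows, while ethyl in compound 2 cost a modest amount, as a 2.4-fold lower number from compound 2 to compound 3 (0.38 log units; beyond the scatter) shows. A result between these two outcomes is expected in this assay. The estimated change is a 1.6-fold higher number from compound 3 to compound 4 (0.20 log units; within the scatter), a small move toward a higher number. Compound 4 is expected to give about 320 nM, with an estimated range of 130 nM to 800 nM.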

Compound 4, half-maximal inhibitory concentration: 410 nM
Estimate against measurement, compound 4: 1.3-fold (0.11 log units) below; the measured number falls inside the stated range.
By their numbers in this assay, from the lowest: compounds 3, 1, 4 and 2 (each within the scatter of the next, the first and the last beyond it).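

In this assay, going by these compounds alone, difluoromethoxy, the only group at this aromatic carbon that carries oxygen, gives a modest loss against hydrogen, with a 2.1-fold higher number from compound 3 to compound 4 (0.31 log units; beyond the scatter) at this position para to a large group. Its other two steps do not separate it from the remaining groups, since a 1.2-fold lower number from compound 2 to compound 4 (0.07 log units; within the scatter) leaves it level with ethyl and a 1.8-fold higher number from compound 1 to compound 4 (0.25 log units; within the scatter) leaves it level with fluoro, even though fluoro itself cannot be told apart from hydrogen, so the four groups form an overlapping run rather than two clear classes. The data shown offer no measurement that explains why this group differs from hydrogen.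

The compounds shown leave open how an amine or a carboxylic acid at this same carbon would read, and whether a chain longer than ethyl would move the number beyond what ethyl and difluoromethoxy give. Because every change here falls on this one carbon, they also leave open whether a methoxy or a chloro group placed elsewhere on that ring would behave in the same way.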